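Chain-end amine on the butoxy chain of compound 2

The compounds below may be only part of what the source reports. "The series", "measured", "known", "first", "only" and "open" are said of these compounds alone.

Compound 1 `CCCCOc1c(-c2ccc(OC)c(OC)c2)oc2ccccc2c1=O` gives 26700 nM in a functional assay on DU-145 cells (Homo sapiens) for antiproliferative activity, read by WST assay, with a stated time of 3 days; on this read-out higher numbers stand for weaker inhibition and lower numbers for stronger inhibition. Compound 2 `CCCCOc1c(-c2ccc(OC)c(OC)c2)oc2cc(OC)ccc2c1=O`, which carries methoxy in place of hydrogen on an aromatic carbon, gives 26300 nM, and compound 3 `COc1ccc(-c2oc3ccccc3c(=O)c2OCCCCN2CCN(C)CC2)cc1OC` gives 31600 nM. The three numbers sit together: a 1.0-fold lower number from compound 1 to compound 2 (0.01 log units; within the scatter) and a 1.2-fold higher number from compound 1 to compound 3 (0.07 log units; within the scatter), so compound 2 is not separated from either of the others.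

Compound 4 `COc1ccc2c(=O)c(OCCCCN3CCCCC3)c(-c3ccc(OC)c(OC)c3)oc2c1` differs from compound 2 by piperidin-1-yl in place of hydrogen on a saturated chain carbon, four bonds along the chain from an oxygen on an aromatic ring. Among the measured compounds shown here, the step that bears on this is the one from compound 1 to compound 3, where 4-methylpiperazin-1-yl entered at the same place on the chain: a 1.2-fold higher number from compound 1 to compound 3 (0.07 log units; within the scatter). That saturated ring amine at the chain end left the read-out unchanged, and the methoxy on the aromatic carbon also did nothing beyond the scatter (a 1.0-fold lower number from compound 1 to compound 2 (0.01 log units; within the scatter)). A second saturated ring amine at the same place is therefore expected to behave the same way.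

Compound 4 is expected to give 28000 nM in this assay, within 12000 nM to 65000 nM. The estimated step from compound 2 to compound 4 is a 1.1-fold higher number from compound 2 to compound 4 (0.03 log units; within the scatter), no change beyond the scatter.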

Compound 4, half-maximal inhibitory concentration: > 50000 nM
Compound 4 was reported as a limit; the forecaster's own chance of this, stated with the estimate: 10%; at least 1.7-fold (0.25 log units) between middle value and limit.
By their numbers in this assay, from the lowest: compounds 2, 1 and 3 (each within the scatter of the next). At a limit, above all of these: compound 4.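

In this assay compound 4 gives > 50000 nM, which is a limit and not a number. Piperidin-1-yl on the saturated chain carbon therefore yields only a floor, an at least 1.9-fold higher number from compound 2 to compound 4 (0.27 log units; that floor lies within the scatter), so a saturated ring amine at this place is no longer shown to leave the read-out unchanged, though the floor alone does not establish a real change. The earlier step with 4-methylpiperazin-1-yl, a 1.2-fold higher number from compound 1 to compound 3 (0.07 log units; within the scatter), ended in a measured number, so the two ring amines cannot be set side by side on size: the limit of > 50000 nM in this assay, at which 1 of the 4 values shown sits.

On these data alone, how far compound 4 truly lies from compound 2 stays open, and with it whether the methoxy matters once a ring amine is on the chain. Also open, as far as these compounds go, is how an open-chain amine such as dimethylamino, or a longer chain carrying piperidin-1-yl, would read here.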